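The compounds below may be only part of what the source reports. "The series", "measured", "known", "first", "only" and "open" are said of these compounds alone.

In an assay on isolated protein for inhibition of DNA topoisomerase 1 (Homo sapiens), with a stated time of 30 min, tested at 100 uM (on this read-out lower numbers stand for a weaker effect and higher numbers for a stronger effect at the one concentration tested), compound 2 `Oc1cccc(-c2cc(-c3ccccc3)nc(-c3cccs3)c2)c1` gives 9.1%. Compound 1 `Oc1ccc(-c2cc(-c3ccccc3)cc(-c3ccc(O)cc3)n2)cc1` gives 0.3% in this assay, and the two numbers lie within the usual scatter of each other, with no order to be read between them. Compound 3 `Oc1cccc(-c2cc(-c3ccccc3)nc(-c3cccnc3)c2)c1` differs from compound 2 in one place: pyridin-3-yl in place of thiophen-2-yl on an aromatic carbon. Among the measured compounds shown here, no measured pair shows what this change does. The expected step in this assay is a number 2.1 percentage points lower from compound 2 to compound 3 (within the scatter), nothing beyond the scatter in either direction, given the reading of compound 2 at 9.1%. Compound 3 is therefore estimated at 7%, within a range from 0% to 20%.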

Compound 3, a percentage reported as inhibition, at one concentration (the size of the read-out at that concentration, not a potency): 8.1%
For compound 3 the middle estimate is 1.1 percentage points below the measured one; measured number inside the range.
By their numbers in this assay, from the lowest: compounds 1, 3 and 2 (each within the scatter of the next).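

In this assay, among the compounds shown here, the first measured pair at this position, on the aromatic carbon next to the ring nitrogen, puts pyridin-3-yl in place of thiophen-2-yl and gives a number 1 percentage points lower from compound 2 to compound 3 (within the scatter). Here, a six-membered aromatic ring with 1 hetero atom can stand in for a five-membered one without a difference beyond the scatter. No evidence at hand bears on this result.

From the compounds shown here alone, whether an amine or a carboxylic acid at this position would move the reading beyond the scatter remains open.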